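From 3-methylphenyl to 4-(trifluoromethyl)phenyl on a sulfonamide nitrogen

The compounds below may be only part of what the source reports. "The series", "measured", "known", "first", "only" and "open" are said of these compounds alone.

Values measured in a functional assay on HeLa cells (Homo sapiens) for inhibition, read by CCK-8 assay, with a stated time of 72 h (on this read-out lower numbers stand for stronger inhibition and higher numbers for weaker inhibition), so far:
Compound 1 `O=C(/C=C/c1cccnc1)NCCCCCCc1ccc(S(=O)(=O)Nc2ccccc2)cc1` gives 377 nM
Compound 2 `O=C(/C=C/c1cccnc1)NCCCc1cccc(S(=O)(=O)Nc2ccccc2)c1` gives 115 nM
Compound 3 `Cc1cccc(NS(=O)(=O)c2cccc(CCCCCCNC(=O)/C=C/c3cccnc3)c2)c1` gives 65.8 nM

Compound 3 has the lowest of the three numbers, yet compound 3 (65.8 nM) and compound 2 (115 nM) lie within the scatter of each other. Compound 1 (377 nM) reads higher than compound 3, and that gap lies beyond the scatter.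

The next compound is compound 4 `O=C(/C=C/c1cccnc1)NCCCCCCc1cccc(S(=O)(=O)Nc2ccc(C(F)(F)F)cc2)c1` which carries 4-(trifluoromethyl)phenyl in place of 3-methylphenyl on a sulfonamide nitrogen. For the measured compounds named here, the three measured compounds differ from one another in more than one place, so no measured pair isolates this exchange and the data give no direct size or direction for it. The expectation therefore starts from compound 3 (65.8 nM) and assumes no change beyond the scatter in this assay for this exchange. The estimated size of the move is a 1.1-fold higher number from compound 3 to compound 4 (0.03 log units; within the scatter) and it is expected to stay within the scatter. The estimated value for compound 4 is 70 nM with a wide expected range (18 nM to 270 nM).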

Compound 4, half-maximal inhibitory concentration: 1450 nM
For compound 4 the middle estimate is 21-fold (1.32 log units) below the measured one, and the stated range ends below it.
By their numbers in this assay, from the lowest: compounds 3 and 2 (each within the scatter of the next); then compound 1; then compound 4.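

In this assay, for the compounds shown here, the exchange of 3-methylphenyl for 4-(trifluoromethyl)phenyl on the sulfonamide nitrogen gives a 22-fold higher number from compound 3 to compound 4 (1.34 log units; beyond the scatter) and is the first single-place comparison in this set, showing that the read-out is sensitive to what this aryl group carries. The two groups have the same count of hydrogen-bond donors and acceptors, no net charge and the same kind of six-membered aromatic ring, so none of these printed features distinguishes them. No measurement available here accounts for the step.

The exchange changes both the substituent and the number in its name, so the compounds shown cannot separate the two. On these data alone, it remains open how 3-(trifluoromethyl)phenyl or 4-methylphenyl would read, and what an amine or a carboxylic acid on this phenyl ring would do.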